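Swapping the terminal ring on compound 1: pyridine to imidazole

The source may hold more compounds than are shown below. What is called first, only, known or untested is meant among the compounds shown, and "the series" means these compounds.

Of the compounds shown here, three have been measured in a functional assay on Sf9 cells for antagonist activity at histamine H2 receptor (Homo sapiens), with stated times of 2 min and 20 min; a higher number here means a more potent compound, by a factor of ten per unit of this negative logarithm, a lower number a less potent compound. Compound 1 `N/C(=N\C(=O)CC(c1ccccc1)c1ccccc1)NCCCc1ccccn1` gives 5.68. Compound 2 `CC(CC(=O)/N=C(\N)NCCCc1ccncc1)c1ccccc1` gives 5.54, which lies within the scatter of compound 1. Compound 3 `CC(CC(=O)/N=C(\N)NCCCc1ccc(CN(C)C)o1)c1ccccc1` gives 6.52, clearly the highest of the three. Compound 1 thus sits second of the three numbers, close to compound 2 and well below compound 3.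

Compound 4 `N/C(=N\C(=O)CC(c1ccccc1)c1ccccc1)NCCCn1ccnc1` has not yet been measured. It differs from compound 1 in one place: 1H-imidazol-1-yl in place of pyridin-2-yl on a saturated chain carbon, three bonds along the chain from an amine nitrogen.

Among the measured compounds shown here, only one measured step bears on this change, the ring swap at the same place a number 0.98 log units higher from compound 2 to compound 3 (beyond the scatter). It shows that exchanging the terminal ring at this position can move the number by close to a whole unit, but the ring entering there was different from the imidazole entering here, so its size cannot be carried over directly. A small to modest change is expected for compound 4, most likely upward, with a wide range.

Compound 4 is expected to give 5.9 in this assay, between 5.3 and 6.6, a step of a number 0.22 log units higher from compound 1 to compound 4 (within the scatter).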

Compound 4, negative logarithm of the antagonist equilibrium constant: 5.82
Beside the measured number, compound 4's estimate is 0.08 log units above it, and the stated range covers the measured number.
By their numbers in this assay, from the lowest: compounds 2, 1 and 4 (each within the scatter of the next); then compound 3.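

Exchanging pyridin-2-yl for 1H-imidazol-1-yl, a six-membered ring with one hetero atom for a five-membered ring with two, gives a number 0.14 log units higher from compound 1 to compound 4 (within the scatter) in this assay. The earlier step at this place, a number 0.98 log units higher from compound 2 to compound 3 (beyond the scatter), showed that a change of terminal ring can shift the number clearly, whereas this result shows that such a change can also leave it within the scatter, even when ring size and hetero atom count both differ. No measurement shown here accounts for this result.

Going by these compounds, whether the 5-((dimethylamino)methyl)furan-2-yl group of compound 3 would raise the number on the core of compound 1 remains open. So does the outcome for 1H-imidazol-4-yl, for 2-aminothiazol-5-yl, or for a four-carbon chain in place of the propyl chain.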